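From 3,5-dimethoxyphenyl to 3,4-dichlorophenyl on the shared core

The compounds below may be only part of what the source reports. "The series", "measured", "known", "first", "only" and "open" are said of these compounds alone.

Measured in a functional assay on HepG2 cells (Homo sapiens) for cytotoxicity, read by MTT assay, with a stated time of 24 h; on this read-out lower numbers stand for stronger inhibition and higher numbers for weaker inhibition:
compound 1 `COc1cc(/C=C2\CN(C)C/C(=C\c3ccc(F)cc3)C2=O)cc(OC)c1`: 6140 nM
compound 2 `COc1cc(/C=C2\CN(C)C/C(=C\c3cccc([N+](=O)[O-])c3)C2=O)cc(OC)c1`: 1840 nM
compound 3 `COc1cc(/C=C2\CN(C)C/C(=C\c3cc(OC)c(OC)c(OC)c3)C2=O)cc(OC)c1`: 890 nM

Of these three, compound 3 has the lowest number, 890 nM, against 1840 nM for compound 2 and 6140 nM for compound 1. Compound 4 `COc1cc(/C=C2\CN(C)C/C(=C\c3ccc(Cl)c(Cl)c3)C2=O)cc(OC)c1OC` differs from compound 3 in one place: 3,4-dichlorophenyl in place of 3,5-dimethoxyphenyl on a double-bonded chain carbon bound to a double-bonded ring carbon. There, 3,4-dichlorophenyl stands in place of 3,5-dimethoxyphenyl on a double-bonded chain carbon bound to a double-bonded ring carbon.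

For the measured compounds named here, only one measured step bears on this change, a swap at the same kind of place: a 3.3-fold lower number from compound 1 to compound 2 (0.52 log units; beyond the scatter). That swap, 3-nitrophenyl in place of 4-fluorophenyl, shows that such a change can move the number modestly. Going by the values given here, compound 1, the only measured compound with a halogen-bearing group, gives the highest number, 6140 nM, though a single compound is thin evidence. A modest move to a higher number is therefore expected in this assay, and the expected step is a 2.2-fold higher number from compound 3 to compound 4 (0.35 log units; beyond the scatter). For compound 4 the estimate is 2000 nM, with an expected range from 700 nM to 5500 nM.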

Compound 4, half-maximal inhibitory concentration: 6960 nM
Estimate against measurement, compound 4: 3.5-fold (0.54 log units) below; measured number outside the range, above it.
By their numbers in this assay, from the lowest: compound 3; then compound 2; then compounds 1 and 4 (each within the scatter of the next).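

In this assay, for the compounds shown here, the swap at this place gives a 7.8-fold higher number from compound 3 to compound 4 (0.89 log units; beyond the scatter), a move to a higher number, whereas the only earlier step at this kind of place, a 3.3-fold lower number from compound 1 to compound 2 (0.52 log units; beyond the scatter), went to a lower number, so changing the group here can shift the number in either direction. The 3,5-dimethoxyphenyl and 3,4-dichlorophenyl groups are both single six-membered aromatic rings of carbon only, yet they are not interchangeable at this place, since the step between them lies beyond the scatter. No measurement at hand gives a cause for this step.

As far as these compounds go, it remains open whether a phenyl group with a single chlorine would give a number closer to that of compound 3 or to that of compound 4. From the compounds shown here alone, how an amine or a carboxylic acid on the phenyl ring would read at this place is also open.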